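Notes on the step from compound 3 to compound 4

A few compounds are considered here, and "the series" means these few. Any claim that something is new, unique, unknown or untested is made for them only; others in the source may bear on it.

In a functional assay on HCT-116 cells (Homo sapiens) for antiproliferative activity, read by CCK-8 assay, with a stated time of 72 h (a lower number here means a stronger inhibitor, a higher number a weaker inhibitor), compound 1 `CCOc1cc(C(C)(C)C)ccc1C1=NC(c2ccc(Cl)cc2)C(c2ccc(Cl)cc2)N1C(=O)NCCCCCCCC(=O)Nc1ccccc1N` gives 9910 nM and compound 2 `CCOc1cc(C(C)(C)C)ccc1C1=NC(c2ccc(Cl)cc2)C(c2ccc(Cl)cc2)N1C(=O)NCCCCCCC(=O)Nc1ccccc1N` gives 10100 nM. The step between them, a 1.0-fold higher number from compound 1 to compound 2 (0.01 log units; within the scatter), lies within the scatter. Compound 3 `CCOc1cc(C(C)(C)C)ccc1C1=NC(c2ccc(Cl)cc2)C(c2ccc(Cl)cc2)N1C(=O)N1CCN(Cc2ccc(C(=O)NO)cc2)CC1` gives 2030 nM, the lowest of the three numbers and beyond the scatter from both of the others.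

Compound 4 `CCOc1cc(C(C)(C)C)ccc1C1=NC(c2ccc(Cl)cc2)C(c2ccc(Cl)cc2)N1C(=O)N1CCN(CCCCCCCC(=O)NO)CC1` has not yet been measured. The change is 6-(hydroxycarbamoyl)hexyl in place of 4-(hydroxycarbamoyl)phenyl on a saturated chain carbon bound to an amine nitrogen in a ring.

For the measured compounds named here, no measured step tests this exchange directly. Going by the values given here, the only measured step, a 1.0-fold higher number from compound 1 to compound 2 (0.01 log units; within the scatter), alters a chain in a different pair of compounds, so it offers limited guidance. On that slender evidence, no shift beyond the scatter is expected in this assay, and the estimated step is a 1.2-fold higher number from compound 3 to compound 4 (0.09 log units; within the scatter). Compound 4 is expected at about 2500 nM, with an estimated range of 800 nM to 7500 nM.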

Compound 4, half-maximal inhibitory concentration: 1710 nM
For compound 4 the middle estimate is 1.5-fold (0.16 log units) above the measured one; measured number inside the range.
By their numbers in this assay, from the lowest: compounds 4 and 3 (each within the scatter of the next); then compounds 1 and 2 (each within the scatter of the next).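

In this assay, 6-(hydroxycarbamoyl)hexyl in place of 4-(hydroxycarbamoyl)phenyl on a saturated chain carbon bound to an amine nitrogen in a ring gives a 1.2-fold lower number from compound 3 to compound 4 (0.07 log units; within the scatter) and so stays within the scatter. At this position, an open chain can thus stand in for the aromatic ring with no measurable shift in antiproliferative potency, whereas the earlier step, a 1.0-fold higher number from compound 1 to compound 2 (0.01 log units; within the scatter), concerned only chain length in another pair. Nothing available explains why the two groups perform alike.

Open, as far as these compounds go, is whether a longer chain at this position, or a carboxylic acid in place of the hydroxycarbamoyl group, would leave the number unchanged. Compounds 1 and 2 differ from compound 3 and compound 4 in more than one place, so the contribution of each end group remains unresolved.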